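The compounds below may be only part of what the source reports. "The series", "measured", "known", "first", "only" and "open" are said of these compounds alone.

Compound 1 `CC1(C)[C@@H]2CC[C@@]1(CS(=O)(=O)N1CCN(c3ccc(Br)cn3)CC1)C(=O)C2` gives 1580 nM in a functional assay on CHO-K1 cells for antagonist activity at C-X-C chemokine receptor type 3 (Homo sapiens), read by FLIPR and calcium flux; a higher number here means a weaker inhibitor, a lower number a stronger inhibitor.
Compound 2 `CC1(C)[C@@H]2CC[C@@]1(CS(=O)(=O)N1CCN(c3ccc(C(F)(F)F)cn3)CC1)C(F)C2` gives 794 nM in this assay.
Compound 3 `CC(=O)NC1C[C@H]2CC[C@]1(CS(=O)(=O)N1CCN(c3ccc(C(F)(F)F)cn3)CC1)C2(C)C` gives 2000 nM in this assay.

Among these three numbers, compound 3 stands highest. Its nearest neighbour is compound 1, and the gap between the two lies within the scatter of repeated measurements, so no order can be read between them. Compound 2 lies furthest away, and the step of a 2.5-fold higher number from compound 2 to compound 3 (0.40 log units; beyond the scatter) is a modest loss of inhibitory strength that does exceed the scatter.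

Compound 4 `CCNC1C[C@H]2CC[C@]1(CS(=O)(=O)N1CCN(c3ccc(C(F)(F)F)cn3)CC1)C2(C)C` differs from compound 3 in one place only: ethyl in place of acetyl on an amine nitrogen. Among the measured compounds shown here, the only measured step that touches this part of the molecule is a 2.5-fold higher number from compound 2 to compound 3 (0.40 log units; beyond the scatter), which shows that altering the group on this saturated ring carbon can move the number, though only modestly. For the measured compounds named here, no measured pair shows what exchanging the acetyl for an ethyl on the amine nitrogen does, so the expectation rests on that single neighbouring step and remains loose. Compound 4 is therefore estimated to land near 1600 nM, with a likely range from 500 nM to 5000 nM. The step from compound 3 to compound 4 in this assay is expected to be a 1.3-fold lower number from compound 3 to compound 4 (0.10 log units; within the scatter), which need not exceed the scatter in either direction.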

Compound 4, half-maximal inhibitory concentration: 7940 nM
Estimate against measurement, compound 4: 5.0-fold (0.70 log units) below, outside the stated range (above it).
By their numbers in this assay, from the lowest: compounds 2, 1 and 3 (each within the scatter of the next, the first and the last beyond it); then compound 4.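

Within this series, the group on the amine nitrogen has a clear effect on the number in this assay: replacing acetyl with ethyl weakens inhibition (a 4.0-fold higher number from compound 3 to compound 4 (0.60 log units; beyond the scatter)). Among the compounds shown here, this change removes the carbonyl and its one hydrogen-bond acceptor, and the earlier compounds gave no view of a change at this nitrogen while the saturated ring carbon kept its nitrogen. Against fluoro on that ring carbon, ethylamino costs more (a 10-fold higher number from compound 2 to compound 4 (1.00 log units; beyond the scatter)) than acetamido does (a 2.5-fold higher number from compound 2 to compound 3 (0.40 log units; beyond the scatter)), so the loss seen earlier depends strongly on what the nitrogen carries, although no measurement here explains why the number rises.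

The two nitrogen groups alone cannot separate the loss of the carbonyl from the change of the whole group, and a methyl, a longer chain such as propyl, or the unsubstituted amine would help to show which matters. A urea or a methanesulfonamide on the same nitrogen would also test whether another group carrying a hydrogen-bond acceptor brings the number back towards that of compound 3 (2000 nM).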